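Dropping the hydroxy: from compound 3 to compound 4

A few compounds are considered here, and "the series" means these few. Any claim that something is new, unique, unknown or untested is made for them only; others in the source may bear on it.

Compound 3 `OCCNCCOc1cccc2ccccc12` gives the lowest number of the three measured in a functional assay for agonist activity at 5-hydroxytryptamine receptor 1B (Homo sapiens) (on this read-out lower numbers stand for stronger inhibition and higher numbers for weaker inhibition), at 107 nM; compound 2 `CN(C)CCCCOc1cccc2ccccc12` gives 470 nM and compound 1 `CC(C)NCCCOc1cccc2ccccc12` gives 7660 nM, with the steps of a 4.4-fold lower number from compound 2 to compound 3 (0.64 log units; beyond the scatter) and a 72-fold lower number from compound 1 to compound 3 (1.85 log units; beyond the scatter) both beyond the scatter. Compound 4 `CCCNCCOc1cccc2ccccc12` differs from compound 3 by methyl in place of hydroxy on a saturated chain carbon, two bonds along the chain from an amine nitrogen. Among the measured compounds shown here, no measured step changes only this group: the steps of a 16-fold lower number from compound 1 to compound 2 (1.21 log units; beyond the scatter), a 72-fold lower number from compound 1 to compound 3 (1.85 log units; beyond the scatter) and a 4.4-fold lower number from compound 2 to compound 3 (0.64 log units; beyond the scatter) each alter the amine substituent together with the chain, so none isolates the hydroxy. Compound 3 is the only anchor. From compound 3 a modest weakening in this assay is expected, a 2.1-fold higher number from compound 3 to compound 4 (0.31 log units; beyond the scatter). Compound 4 is therefore estimated at about 220 nM in this assay, within 60 nM to 800 nM.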

Compound 4, inhibition constant: 200 nM
The estimate for compound 4 lay 1.1-fold (0.04 log units) above the measured number; the range from low to high includes it.
By their numbers in this assay, from the lowest: compounds 3 and 4 (each within the scatter of the next); then compound 2; then compound 1.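

In this assay, the hydroxy on a saturated chain carbon, two bonds along the chain from an amine nitrogen, gives way to methyl with a 1.9-fold higher number from compound 3 to compound 4 (0.27 log units; within the scatter), so at this position the change stays within the scatter even though the hydrogen-bond donor and acceptor counted on the hydroxy are gone. Without the hydroxy the propylamino compound still stands clear of the other two, with a 2.4-fold lower number from compound 2 to compound 4 (0.37 log units; beyond the scatter) and a 38-fold lower number from compound 1 to compound 4 (1.58 log units; beyond the scatter). Nothing available accounts for this result. On these data alone, whether a methoxy or a carboxylic acid at the same chain end would read like hydroxy and methyl remains open. So does the effect of a longer chain on the nitrogen.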